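Working notes: from compound 3 to compound 4

The source may report more compounds than this note shows. Statements on the series, on what has been measured and on what is new or still open speak of the compounds shown alone.

Measured in a functional assay on HL-60 cells (Homo sapiens) for cytotoxicity, read by WST assay, with a stated time of 48 h; on this read-out lower numbers stand for stronger inhibition and higher numbers for weaker inhibition:
compound 1 `COc1cc(C(c2ccc(O)c(OC)c2)[C@H](CC(C)C)C(C)C)ccc1O`: 9600 nM
compound 2 `COc1cc(C(c2ccc(O)c(OC)c2)[C@H](C)[C@H](C)CF)ccc1O`: 56000 nM
compound 3 `COc1cc(C(c2ccc(O)c(OC)c2)[C@H](CO)C(C)C)ccc1O`: > 100000 nM

Compound 3 stands at a limit of the assay and has no number: the limit of > 100000 nM in this assay, at which 1 of the 3 values shown sits.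

The next structure is compound 4 `COC[C@@H](C)[C@H](C)C(c1ccc(O)c(OC)c1)c1ccc(O)c(OC)c1`. The change is 2-(methoxymethyl)-1-methylpropyl in place of 1-(hydroxymethyl)-2-methylpropyl on a saturated chain carbon bound to two aromatic carbons, with 2-(methoxymethyl)-1-methylpropyl in place of 1-(hydroxymethyl)-2-methylpropyl on a saturated chain carbon bound to two aromatic carbons.

For the measured compounds named here, three measured steps bear on this change. The closest is an at least 1.7-fold higher number from compound 2 to compound 3 (0.25 log units; that floor lies within the scatter), and its floor gives no firm size. The other two, a 5.8-fold higher number from compound 1 to compound 2 (0.77 log units; beyond the scatter) and an at least 10-fold higher number from compound 1 to compound 3 (1.01 log units; beyond the scatter), show that changes at this place can move this assay beyond the scatter.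

Compound 2, at 56000 nM, carries 2-(fluoromethyl)-1-methylpropyl, the group whose name lies closest to the entering one, so a result in that region is expected. A modest move to a lower number is therefore expected, though a second result at the limit remains possible.

The estimated outcome is an at least 2.5-fold lower number from compound 3 to compound 4 (0.39 log units; beyond the scatter).

For compound 4 the expected value is 40000 nM, with an estimated range of 15000 nM to 95000 nM.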

Compound 4, half-maximal inhibitory concentration: 73000 nM
Estimate against measurement, compound 4: 1.8-fold (0.26 log units) below, and the stated range covers the measured number.
By their numbers in this assay, from the lowest: compound 1; then compounds 2 and 4 (each within the scatter of the next). At a limit, above all of these: compound 3.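

In this assay, 2-(methoxymethyl)-1-methylpropyl in place of 2-(fluoromethyl)-1-methylpropyl gives a 1.3-fold higher number from compound 2 to compound 4 (0.12 log units; within the scatter), so these two groups cannot be told apart at this position. In place of 1-isopropyl-3-methylbutyl, the same group gives a 7.6-fold higher number from compound 1 to compound 4 (0.88 log units; beyond the scatter), so compound 4, like compound 2, stays clearly weaker than compound 1. In place of 1-(hydroxymethyl)-2-methylpropyl, it gives an at least 1.3-fold lower number from compound 3 to compound 4 (0.13 log units; that floor lies within the scatter). This floor gives no usable size, because compound 3 has only a limit and no number: the limit of > 100000 nM in this assay, at which 1 of the 4 values shown sits.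

Still open, on these data alone, is whether an amine or a carboxylic acid, placed on a saturated chain carbon bound to two aromatic carbons, would leave the number in the region of compound 2 and compound 4. Also open, as far as these compounds go, is whether a longer chain made only of carbon would bring it closer to compound 1.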